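The source may report more compounds than this note shows. Statements on the series, on what has been measured and on what is new or still open speak of the compounds shown alone.

Three compounds share one core, differing only in the aryl group on the amine nitrogen. Compound 1 `S=c1oc(-c2ccc3c(c2)OCCO3)nn1CNc1ccccc1` carries a plain phenyl; compound 2 `Fc1cccc(F)c1NCn1nc(-c2ccc3c(c2)OCCO3)oc1=S` a 2,6-difluorophenyl; compound 3 `Cc1ccccc1NCn1nc(-c2ccc3c(c2)OCCO3)oc1=S` a 2-methylphenyl. In a functional assay, with a stated time of 6 min (on this read-out higher numbers stand for weaker inhibition and lower numbers for stronger inhibition), compound 1 gives 5140 nM, compound 2 gives 3320 nM and compound 3 gives 3450 nM. Compound 2 has the lowest of the three numbers, but the steps to it are a 1.5-fold lower number from compound 1 to compound 2 (0.19 log units; within the scatter) and a 1.0-fold higher number from compound 2 to compound 3 (0.02 log units; within the scatter), both within the scatter, so no ordering can be read from them; the step of a 1.5-fold lower number from compound 1 to compound 3 (0.17 log units; within the scatter) is likewise within the scatter.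

Compound 4 `Cc1ccc(NCn2nc(-c3ccc4c(c3)OCCO4)oc2=S)cc1` is next. The change from compound 2 is 4-methylphenyl in place of 2,6-difluorophenyl on an amine nitrogen. For the measured compounds named here, the steps that bear on it, from compound 1 to compound 2 and from compound 2 to compound 3, both vary the aryl group on the same nitrogen and both stay within the scatter, so in this assay no step beyond the scatter is expected in either direction. Compound 4 is therefore expected to give about 3800 nM in this assay, between 1700 nM and 8500 nM, an expected step of a 1.1-fold higher number from compound 2 to compound 4 (0.06 log units; within the scatter) from compound 2.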

Compound 4, half-maximal inhibitory concentration: 5700 nM
For compound 4 the middle estimate is 1.5-fold (0.18 log units) below the measured one, within the range that was stated.
By their numbers in this assay, from the lowest: compounds 2, 3, 1 and 4 (each within the scatter of the next).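

In this assay, exchanging the aryl group for 4-methylphenyl gives a 1.7-fold higher number from compound 2 to compound 4 (0.23 log units; within the scatter) and, where only the place of the methyl on the ring differs, a 1.7-fold higher number from compound 3 to compound 4 (0.22 log units; within the scatter); both steps stay within the scatter. Adding the methyl to the plain phenyl gives a 1.1-fold higher number from compound 1 to compound 4 (0.04 log units; within the scatter), also within the scatter, so this change on the amine nitrogen gives no step that can be read, and all four aryl groups remain indistinguishable here. Nothing is available that would bear on this result.

As far as these compounds go, it remains open whether any change at this position would give a step beyond the scatter, for example a carboxylic acid or an amine on the phenyl ring. A longer chain or a saturated cyclohexyl ring in place of the aryl group is equally untested by these compounds.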